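The source may hold more compounds than are shown below. What is called first, only, known or untested is meant among the compounds shown, and "the series" means these compounds.

Working notes on the series. Of the compounds shown here, two have numbers so far in a physicochemical assay for lipophilicity; on this read-out higher numbers stand for higher lipophilicity and lower numbers for lower lipophilicity. Compound 1 `COc1cc(/C=C2\CCC/C(=C\c3ccccc3[N+](=O)[O-])C2=O)cc(OC)c1OC` gives 4.33, and compound 2 `Cc1ccc(/C=C2\CCC/C(=C\c3cccc([N+](=O)[O-])c3)C2=O)cc1` gives 5.35. Compound 1 is therefore the lower of the two, and the gap to compound 2 lies beyond the scatter.

Compound 3 `COc1cc(/C=C2\CCC/C(=C\c3cccc([N+](=O)[O-])c3)C2=O)cc(OC)c1OC` has not yet been measured. It departs from compound 1 in one place, with 3-nitrophenyl in place of 2-nitrophenyl on a double-bonded chain carbon bound to a double-bonded ring carbon. The two compounds have the same atoms, joined differently, and the counts for the two groups match. Among the compounds with values here, no measured pair shows this kind of change, so the expectation rests on that match and on compound 1 at 4.33. A step within the scatter of this assay is expected, with no firm direction. The estimate amounts to a number 0.07 log units higher from compound 1 to compound 3 (within the scatter), a shift expected to stay within the scatter. For compound 3 the expected value is 4.4, with an estimated range from 4 to 4.8.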

Compound 3, partition coefficient: 4.53
For compound 3 the middle estimate is 0.13 log units below the measured one, and the stated range covers the measured number.
By their numbers in this assay, from the lowest: compounds 1 and 3 (each within the scatter of the next); then compound 2.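

In this assay, within the data shown here, 3-nitrophenyl in place of 2-nitrophenyl on a double-bonded chain carbon bound to a double-bonded ring carbon gives a number 0.20 log units higher from compound 1 to compound 3 (within the scatter), and this is the first pair that differs in this one place. On the core of compound 1, this read-out therefore does not tell the two nitrophenyl groups apart, although they are joined differently and match in every count. Nothing on hand explains the closeness of the two numbers.

From the compounds shown here alone, the result rests on a single pair, so it stays open whether 2-nitrophenyl in place of 3-nitrophenyl on the core of compound 2 would also give a step within the scatter. Going by these compounds, it also stays open how far this position tolerates change in this assay when the nitro group itself gives way to an amine, a carboxylic acid or a longer chain, since both groups compared here are nitrophenyl groups of identical composition.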